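Taking the methoxy off compound 2

This account rests on a few compounds, and the source may have more. Where it says the series, first, only, none or still open, it means among the compounds named here.

Measured in a functional assay on UACC-62 cells (Homo sapiens) for inhibition, read by sulforhodamine B assay, with a stated time of 48 h, tested at 10 uM; a higher number here means more inhibition of growth at the concentration tested, a lower number less inhibition of growth
compound 1 (`CC(=O)c1ccc(NC(=O)Cn2nc(-c3ccc(Cl)cc3)nc2N)cc1`) gives 6.29%
compound 2 (`COc1ccc(-c2nc3sc(-c4ccccc4)cn3n2)cc1`) gives 42%

Compound 2 stands highest of these two numbers, and the gap down to compound 1 lies beyond the usual scatter. Going by the values given here, the two structures differ in more than one place, so no measured step speaks to a single change.

Still to be measured is compound 3 (`c1ccc(-c2nc3sc(-c4ccccc4)cn3n2)cc1`), which keeps the core of compound 2 and carries hydrogen in place of methoxy on an aromatic carbon, para to a large group (hydrogen in place of methoxy on an aromatic carbon). Among the compounds with values here, the data hold no measured example of this change, so its direction cannot be read from them. Within the data shown here, the expectation rests on compound 2 at 42% as the only measured compound with this core. A small fall is expected, not clearly beyond the scatter, and the estimated size is a number 7 percentage points lower from compound 2 to compound 3 (within the scatter) in this assay for this one change. For compound 3 the estimate is 35% as the expected value, with an expected range from 15% to 55% in this read-out.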

Compound 3, percent growth inhibition at one concentration: 33%
For compound 3 the middle estimate is 2 percentage points above the measured one, and the stated range covers the measured number.
By their numbers in this assay, from the lowest: compound 1; then compounds 3 and 2 (each within the scatter of the next).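

In this assay, going by these compounds alone, hydrogen in place of methoxy on an aromatic carbon, para to a large group, gives a number 9 percentage points lower from compound 2 to compound 3 (within the scatter) and provides the first single-place step. With hydrogen at this position, compound 3 reads 33% at the one concentration tested, so on this core the read-out does not depend on the methoxy by more than the usual scatter, and this single step gives no firm direction for the change. No measurement available here bears on why the step has this size.

Going by these compounds, whether an amine, a carboxylic acid or a longer chain such as ethoxy on this same aromatic carbon would move the number beyond the scatter remains open, as one step at one position says little about other groups there. Also open, on these data alone, are how these compounds behave at other concentrations, since each value stands at a single one, and whether a change elsewhere on the shared core would give a step beyond the scatter.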